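Dropping a nitro group from a fused ring core

The source may report more compounds than this note shows. Statements on the series, on what has been measured and on what is new or still open speak of the compounds shown alone.

Measured so far:
compound 1, `O=c1c2cc([N+](=O)[O-])cnc2sn1-c1ccc([N+](=O)[O-])cc1`, 11800 nM
compound 2, `O=c1c2ccc([N+](=O)[O-])cc2sn1Cc1ccccc1`, 7660 nM
compound 3, `O=c1c2cccnc2sn1Cc1ccccc1`, 23000 nM

All three were tested in an assay for inhibition of histone acetyltransferase KAT2B (Homo sapiens), read by fluorescence; on this read-out lower numbers stand for stronger inhibition and higher numbers for weaker inhibition. Compound 1 carries two nitro groups, one on the fused core and one on the aryl ring attached to the ring nitrogen. Its number is within the usual scatter of both compound 2 and compound 3, so the three measured compounds cannot be ranked against each other with confidence; none is clearly the strongest or weakest.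

Compound 4, `O=c1c2cccnc2sn1-c1ccc([N+](=O)[O-])cc1`, has not yet been measured in this assay. It differs from compound 1 in one place: hydrogen in place of nitro on an aromatic carbon. The nitro group on the aryl ring stays. For the measured compounds named here, no measured pair shows this exact change on its own, so the size of the step is uncertain. The expectation is a modest weakening, a step from compound 1 to compound 4 of about a 1.7-fold higher number from compound 1 to compound 4 (0.23 log units; within the scatter), close to the edge of the scatter. Compound 4 is therefore estimated at 20000 nM, with a likely range from 8000 nM to 60000 nM.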

Compound 4, half-maximal inhibitory concentration: 4100 nM
Compound 4: middle estimate off by 4.9-fold (0.69 log units), on the high side; measured number outside the range, below it.
By their numbers in this assay, from the lowest: compounds 4, 2, 1 and 3 (each within the scatter of the next, the first and the last beyond it).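

In this assay, putting hydrogen in place of nitro on the aromatic carbon of the six-membered ring with 1 nitrogen gives a 2.9-fold lower number from compound 1 to compound 4 (0.46 log units; beyond the scatter) and thus stronger inhibition, a modest step beyond the scatter. For the compounds shown here, this is the first pair here that differs in one place only, and it shows that the nitro group at this position is not needed for inhibition, as compound 4 keeps only the nitro group on the aryl ring. Nothing available explains why the number falls when this group leaves.

As far as these compounds go, what an amine or a methoxy group on this same carbon would do remains open. From the compounds shown here alone, it is also open whether hydrogen in place of the remaining nitro group on the aryl ring would shift the number in the same direction.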